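Adding Fluorine to Compound 3: An Expected Solubility Outcome

The source may hold more compounds than are shown below. What is called first, only, known or untested is meant among the compounds shown, and "the series" means these compounds.

Among the compounds with values here, compound 3 `COc1cccc(CNCCCNc2ccnc3cc(Cc4ccccc4)ccc23)c1O` gives 4200 nM in a physicochemical assay for solubility, with a stated time of 18 h, at pH 7.4 (on this read-out lower numbers stand for lower solubility and higher numbers for higher solubility), the lowest of the three numbers measured so far; compound 1 `c1ccc(-c2ccc3c(NCCCNCc4ccco4)ccnc3c2)cc1` gives 32000 nM and compound 2 `Fc1ccc(-c2ccc3c(NCCCNCc4ccco4)ccnc3c2)cc1` gives 32000 nM in this assay. Compound 4 `COc1cccc(CNCCCNc2ccnc3cc(Cc4ccc(F)cc4)ccc23)c1O` differs from compound 3 only by fluoro in place of hydrogen on an aromatic carbon, placed on an aromatic carbon of a six-membered aromatic ring of carbon only, para to a large group. Within the data shown here, one measured step bears directly on this change: the same exchange of fluoro for hydrogen gave no change at the digits printed from compound 1 to compound 2 (within the scatter) in this assay. Among the measured compounds shown here, no other step is available. The expected result for compound 4 is therefore no change beyond the scatter, no change at the digits printed from compound 3 to compound 4 (within the scatter). Compound 4 is estimated at 4200 nM, in a range from 2000 nM to 9000 nM in this assay.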

Compound 4, solubility: 4200 nM
Compound 4: middle estimate and measured number agree at the digits printed; the measured number falls inside the stated range.
By their numbers in this assay, from the lowest: compounds 3 and 4 (each within the scatter of the next); then compounds 1 and 2 (each within the scatter of the next).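

In this assay, phenyl to 4-fluorophenyl on the benzyl group gave no change at the digits printed from compound 3 to compound 4 (within the scatter), so this position on the benzyl group tolerates the exchange without a change beyond the scatter. The exchange has now given the same reading in two separate pairs, the earlier one being no change at the digits printed from compound 1 to compound 2 (within the scatter), and neither pair goes against the other. No measurement shown here explains this result.

The compounds shown leave open what a different group at this position, such as trifluoromethyl, an amine or a carboxylic acid, would do to the number.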